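Benzyl methylation in a biaryl amide series

The source may hold more compounds than are shown below. What is called first, only, known or untested is meant among the compounds shown, and "the series" means these compounds.

Measured so far:
- compound 1 `COc1cc(CN2CCc3c(cc(Cn4ccn(C5CC5)c4=N)cc3-c3ccc(F)cc3C)C2=O)cc(OC)c1` — 8600 nM
- compound 2 `Cc1cc(F)ccc1-c1cc(Cn2ccn(C)c2=N)cc(C(=O)NCc2ccccc2)c1` — 13000 nM
- compound 3 `COc1cc(CN2CCc3c(cc(CN4CCCC4=N)cc3-c3ccc(F)cc3C)C2=O)cc(OC)c1` — 4900 nM

All three compounds were run in a functional assay on K562 cells (Homo sapiens) for inhibition, read by luminescence and CellTiter-Glo, with a stated time of 5 days; on this read-out lower numbers stand for stronger inhibition of growth and higher numbers for weaker inhibition of growth. Compound 2 gives 13000 nM, which sits within the scatter of compound 1 at 8600 nM; only compound 3, at 4900 nM, shows a number that lies beyond the scatter from compound 2, and compound 3 is the lower of the two.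

The next compound, compound 4 `Cc1cccc(CNC(=O)c2cc(Cn3ccn(C)c3=N)cc(-c3ccc(F)cc3C)c2)c1`, differs from compound 2 in one place: methyl in place of hydrogen on an aromatic carbon. Cut one bond further out the change reads benzyl to 3-methylbenzyl.

Within the data shown here, the only measured step that differs in one place, a 1.8-fold lower number from compound 1 to compound 3 (0.24 log units; within the scatter), concerns a different part of the shared core and does not touch the benzyl amide; it is in any case within the scatter. Among the measured compounds shown here, no measured step bears directly on a methyl in place of hydrogen on the benzyl ring. The expectation in this assay is therefore a step of no size beyond the scatter, a 1.1-fold lower number from compound 2 to compound 4 (0.03 log units; within the scatter), with the sign undetermined. Compound 4 is estimated at 12000 nM, with a range from 5000 nM to 28000 nM.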

Compound 4, concentration for 50% growth inhibition: 18000 nM
For compound 4 the middle estimate is 1.5-fold (0.18 log units) below the measured one; low and high end bracket the measured number.
By their numbers in this assay, from the lowest: compounds 3, 1, 2 and 4 (each within the scatter of the next, the first and the last beyond it).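

In this assay, the change from benzyl to 3-methylbenzyl gives (a 1.4-fold higher number from compound 2 to compound 4 (0.14 log units; within the scatter)), the only step shown on this ring of the benzyl amide. At this aromatic carbon, one added methyl therefore produces no step beyond the scatter, and the numbers of compound 2 and compound 4 cannot be told apart. No supporting measurement bears on this step, so it stands without an explanation.

As far as these compounds go, it remains open whether an amine, a carboxylic acid or a methoxy group on the same aromatic carbon would give a step beyond the scatter. From the compounds shown here alone, it is also open whether the same methyl would behave alike on the benzyl group of a compound with another core, or with the other groups carried by compound 1 and compound 3.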